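A few compounds are considered here, and "the series" means these few. Any claim that something is new, unique, unknown or untested is made for them only; others in the source may bear on it.

Measured compounds:
Compound 1 `NC(=O)c1c(NC(=O)c2ccccc2Cl)sc2c1CCN(C(=S)Nc1ccccc1)C2` gives 5940 nM in a functional assay on HL-60 cells (Homo sapiens) for antiproliferative activity, with a stated time of 24 h; a lower number here means a stronger inhibitor, a higher number a weaker inhibitor.
Compound 2 `NC(=O)c1c(NC(=O)c2ccccc2)sc2c1CCN(C(=S)Nc1ccccc1Cl)C2` gives 13800 nM in this assay.
Compound 3 `NC(=O)c1c(NC(=O)c2ccccc2C(F)(F)F)sc2c1CCN(C(=S)Nc1ccccc1Cl)C2` gives 17600 nM in this assay.

Compound 2 stands second highest of the three numbers. Its nearest neighbour is compound 3, reached by a 1.3-fold higher number from compound 2 to compound 3 (0.11 log units; within the scatter), a step within the scatter. Among the measured compounds shown here, its furthest neighbour is compound 1, whose value is lower by a margin beyond the scatter, though compound 1 and compound 2 differ in two places, so no single step connects them.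

The unmeasured compound 4 `NC(=O)c1c(NC(=O)c2ccccc2)sc2c1CCN(C(=S)Nc1ccccc1)C2` differs from compound 2 by hydrogen in place of chloro on an aromatic carbon. For the measured compounds named here, no measured step removes a chloro on either aromatic ring, so the only step on record, from compound 2 to compound 3, concerns a different ring and a different group, and it was within the scatter. On this thin basis compound 4 is expected to stay close to compound 2, with the step of a 1.2-fold lower number from compound 2 to compound 4 (0.06 log units; within the scatter) not clearly beyond the scatter in either direction. Compound 4 is therefore estimated at 12000 nM in this assay, with a plausible range from 5000 nM to 30000 nM.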

Compound 4, half-maximal inhibitory concentration: > 50000 nM
Compound 4 was reported as a limit; the forecaster's own chance of this, stated with the estimate: 10%; middle value at least 4.1-fold (0.61 log units) from the limit.
By their numbers in this assay, from the lowest: compound 1; then compounds 2 and 3 (each within the scatter of the next). At a limit, above all of these: compound 4.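

Compound 4 is reported only as a limit: the limit of > 50000 nM in this assay, at which 1 of the 4 values shown sits.

Among the compounds shown here, removing a chloro had no step on record before, and now it has two, both beyond the scatter and both in the same direction: an at least 3.6-fold higher number from compound 2 to compound 4 (0.55 log units; beyond the scatter) and an at least 8.4-fold higher number from compound 1 to compound 4 (0.92 log units; beyond the scatter). In compound 2 the chloro sits on one of the two six-membered aromatic rings of carbon only, and in compound 1 it sits on the other, so in this assay a single chloro on either ring separates a measurable number from the limit, while the trifluoromethyl step, a 1.3-fold higher number from compound 2 to compound 3 (0.11 log units; within the scatter), stayed within the scatter with the chloro kept in place. All three compounds with a chloro give measured numbers, and none of the compounds shown goes against this, though the limit means that the full size of both steps is unknown and the compounds shown do not explain why the chloro matters.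

As far as these compounds go, whether a methyl, a methoxy or an amine in the place of the chloro would keep the number as low remains open. So does whether a chloro on both rings at once would lower it further.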